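The source may hold more compounds than are shown below. What is called first, only, known or untested is meant among the compounds shown, and "the series" means these compounds.

Compound 1 `Nc1cn(COCCO)c(=O)[nH]c1=O` and compound 2 `CCc1cn(COCCO)c(=S)[nH]c1=O` share a core and were both tested in a functional assay on HepG2 cells (Homo sapiens) for cytotoxicity, read by MTT assay; a lower number here means that less compound is tolerated, a higher number that more compound is tolerated. For compound 1 the result is a limit of the measurement, > 497000 nM, not a number. For compound 2 the result is likewise a limit, > 478000 nM. Compound 1 thus stands at the edge of what could be read, and the other value shown sits at a limit as well (the limit of > 478000 nM in this assay, at which 1 of the 2 values shown sits). The step to compound 3 `O=c1[nH]c(=O)n(COCCO)cc1CO` puts (hydroxymethyl in place of amino on an aromatic carbon). No measured step of this kind exists among the compounds shown, so the expectation for compound 3 in this assay is no change beyond the scatter, a step that the limit leaves unreadable from compound 1 to compound 3 that most likely ends again at a limit rather than a number. Compound 3 is therefore estimated at 500000 nM, with a range from 250000 nM to 1000000 nM.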

Compound 3, half-maximal cytotoxic concentration: > 476000 nM
Compound 3 was reported as a limit; the forecaster's own chance of this, stated with the estimate: 85%; the middle value is on the limit's open side.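

Compound 1 and compound 3 are both reported as limits in this assay, not as numbers, and the step between them cannot be read. The compounds shown leave open what concentration, if any, gives the half-maximal cytotoxic effect, and whether hydroxymethyl in place of amino alters it.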